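A few compounds are considered here, and "the series" means these few. Any claim that something is new, unique, unknown or untested is made for them only; others in the source may bear on it.

Measured compounds:
compound 1, `COc1cc(-c2ccnc3cc(-c4ccc(F)cc4)nn23)cc(OC)c1OC`, 5030 nM
compound 2, `COc1cc(-c2ccnc3cc(-c4ccccc4)nn23)cc(OC)c1OC`, 3880 nM
compound 3, `COc1cc(-c2ccnc3cc(-c4cccc(C)c4)nn23)cc(OC)c1OC`, 6150 nM

All three numbers come from a functional assay on HCT-116 cells (Homo sapiens) for inhibition, read by CCK-8 assay, with a stated time of 48 h; on this read-out lower numbers stand for stronger inhibition and higher numbers for weaker inhibition. Compound 1 stands second highest of the three, with compound 3 nearest and compound 2 furthest; both gaps lie within the scatter, so no order among them can be read. The two steps that change the aryl substituent on the shared core say the same: a 1.3-fold lower number from compound 1 to compound 2 (0.11 log units; within the scatter), and a 1.2-fold higher number from compound 1 to compound 3 (0.09 log units; within the scatter), and the pairing of the other two, a 1.6-fold higher number from compound 2 to compound 3 (0.20 log units; within the scatter), likewise stays within the scatter.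

Compound 4, `COc1ccc(-c2cc3nccc(-c4cc(OC)c(OC)c(OC)c4)n3n2)cc1`, is not yet measured. Its difference from compound 1 is methoxy in place of fluoro on an aromatic carbon. Among the measured compounds shown here, no measured step introduces a methoxy at this position, so none bears on it directly; the steps from compound 1 to compound 2 and from compound 1 to compound 3 are the only guidance and show that exchanges at this aryl ring have left the number where it was. The step from compound 1 to compound 4 in this assay is therefore expected to stay within the scatter, a 1.0-fold lower number from compound 1 to compound 4 (0.00 log units; within the scatter), in no firm direction. For compound 4 the estimate in this assay is 5000 nM, with a range from 2500 nM to 10000 nM.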

Compound 4, half-maximal inhibitory concentration: 404 nM
Estimate against measurement, compound 4: 12-fold (1.09 log units) above; the whole stated range lies above it.
By their numbers in this assay, from the lowest: compound 4; then compounds 2, 1 and 3 (each within the scatter of the next).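

In this assay, the aryl ring on the shared core no longer looks like the insensitive position that compounds 1, 2 and 3 suggested: 4-methoxyphenyl stands apart from all three, with a 12-fold lower number from compound 1 to compound 4 (1.10 log units; beyond the scatter), a 9.6-fold lower number from compound 2 to compound 4 (0.98 log units; beyond the scatter) and a 15-fold lower number from compound 3 to compound 4 (1.18 log units; beyond the scatter), each beyond the scatter. The gain does not extend to substitution on this ring in general, since fluoro at the same place in compound 1 and the 3-methylphenyl ring of compound 3 cannot be told apart from the unsubstituted phenyl of compound 2; among these four compounds, it is tied to methoxy alone. Nothing available accounts for the difference between methoxy and fluoro at this place.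

Going by these compounds, it remains open whether the step depends on methoxy itself or would also appear with a hydroxy group, an ethoxy group or a dimethylamino group at this place, or with methoxy elsewhere on the ring, as in 3-methoxyphenyl. The rest of the shared core is the same in all four compounds, so whether the step carries over to other cores is also unknown.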